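A few compounds are considered here, and "the series" means these few. Any claim that something is new, unique, unknown or untested is made for them only; others in the source may bear on it.

Series notes. Compound 1 `CN1CCN(c2nc(Oc3ccc(C#N)cc3)nc(-c3ccc(N4C(=O)CSC4c4ccccc4)cc3)n2)CC1` has no result in an ADME assay on Vero cells (Chlorocebus sabaeus) for cytotoxicity, read by MTT assay, with a stated time of 72 h (on this read-out higher numbers stand for weaker inhibition and lower numbers for stronger inhibition), and is carried as "not determined" (no result reported) there. Compound 2 `CN1CCN(c2nc(Oc3ccc(C#N)cc3)nc(-c3ccc(N4C(=O)CSC4c4ccc(O)cc4)cc3)n2)CC1` carries the hydroxy analogue of the same scaffold. In this assay compound 2 gives > 62.5 ug/mL, which is a limit of the assay rather than a number. Compound 2 therefore stands at the limit of > 62.5 ug/mL in this assay, at which 1 of the 2 values shown sits, and no numbered value in this series sits below it or above it for comparison.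

Compound 3 `COc1ccc(C2SCC(=O)N2c2ccc(-c3nc(Oc4ccc(C#N)cc4)nc(N4CCN(C)CC4)n3)cc2)cc1` is the next member, differing from compound 2 by methyl in place of hydrogen on an oxygen on an aromatic ring. Among the compounds with values here, no measured step between two numbered values exists here, so the expected step from compound 2 to compound 3 is set at a step that the limit leaves unreadable from compound 2 to compound 3, that is none beyond the scatter, resting only on the limit recorded for compound 2 > 62.5 ug/mL. For compound 3 the estimate in this assay is 70 ug/mL, with a range from 30 ug/mL to 160 ug/mL.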

Compound 3, half-maximal inhibitory concentration: > 62.5 ug/mL
Compound 3 was reported as a limit; the forecaster's own chance of this, stated with the estimate: 70%; the middle value is on the limit's open side.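

In this assay compound 3 gives > 62.5 ug/mL, a limit of the assay and not a number. Compound 2 also stands at a limit, so no step can be read between compound 2 and compound 3. The compounds shown leave open what number either compound would give, and whether hydroxy to methoxy shifts it at all.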